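Nitro to chloro on the fused ring of compound 2

The compounds below may be only part of what the source reports. "The series", "measured", "known", "first", "only" and "open" are said of these compounds alone.

Working notes on the series. Of the compounds shown here, two have been measured in a functional assay on A-375 cells (Homo sapiens) for antiproliferative activity, read by CCK-8 assay, with a stated time of 72 h, tested at 8 uM; a lower number here means a weaker effect, a higher number a stronger effect of the compound at the concentration tested. Compound 1 `Nc1ccccc1NC(=O)c1ccc(CSC(=S)N2CCN(Cc3ccccn3)CC2)cc1` gives 82.4%. Compound 2 `Nc1ccccc1NC(=O)c1ccc(CSC(=S)N2CCc3cc([N+](=O)[O-])ccc32)cc1` gives 29.5% in this assay, the lower of the two numbers; compound 1 stands higher by a margin beyond the scatter. Compound 3 `Nc1ccccc1NC(=O)c1ccc(CSC(=S)N2CCc3cc(Cl)ccc32)cc1` awaits measurement. The change from compound 2 to compound 3 is chloro in place of nitro on an aromatic carbon. Within the data shown here, no measured pair shows a change of this kind, so a moderate upward move in this assay is expected, roughly a number 12.5 percentage points higher from compound 2 to compound 3 (beyond the scatter). Compound 3 is expected to give about 42%, between 18% and 68%.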

Compound 3, a percentage reported as inhibition, at one concentration (the size of the read-out at that concentration, not a potency): 82.3%
Beside the measured number, compound 3's estimate is 40.3 percentage points below it; the whole stated range lies below it.
By their numbers in this assay, from the lowest: compound 2; then compounds 3 and 1 (each within the scatter of the next).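

Chloro in place of nitro on this aromatic carbon gives in this assay the series' first step at a single place: a number 52.8 percentage points higher from compound 2 to compound 3 (beyond the scatter). The group on this carbon of the six-membered aromatic ring therefore strongly affects the read-out at the concentration tested. Nothing available explains the size of this step.

Going by these compounds, how an amine, a methoxy group or plain hydrogen on this carbon would compare with chloro and nitro remains open. Also open, on these data alone, is whether chloro would give a similar read-out on the other carbons of this ring.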